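Phenyl for Cyclohexyl on the Methylated Anilide Series

The source may report more compounds than this note shows. Statements on the series, on what has been measured and on what is new or still open speak of the compounds shown alone.

Three compounds have been measured in a functional assay on A-375 cells (Homo sapiens) for antiproliferative activity, read by MTT assay, with a stated time of 48 h; a lower number here means a stronger inhibitor, a higher number a weaker inhibitor:
compound 1 `Nc1nc(CC2CCCCC2)c(-c2ccccc2Br)n1CC(=O)Nc1ccccc1` gives 40600 nM
compound 2 `Nc1nc(Cc2ccccc2)c(-c2ccccc2Br)n1CC(=O)Nc1ccccc1` gives 5200 nM
compound 3 `Cc1ccc(NC(=O)Cn2c(N)nc(CC3CCCCC3)c2-c2ccccc2Br)cc1` gives 17500 nM

Compound 4 `Cc1ccc(NC(=O)Cn2c(N)nc(Cc3ccccc3)c2-c2ccccc2Br)cc1` has not yet been measured in this assay. It is derived from compound 3 by the change (phenyl in place of cyclohexyl on a saturated chain carbon bound to an aromatic carbon). The same change, at the same place, has been measured once already, from compound 1 to compound 2, where it gave a 7.8-fold lower number from compound 1 to compound 2 (0.89 log units; beyond the scatter). The two starting points of these pairs differ from each other by methyl in place of hydrogen on an aromatic carbon, and that difference gave a 2.3-fold lower number from compound 1 to compound 3 (0.37 log units; beyond the scatter). Compound 4 therefore carries both changes relative to compound 1, and among the three measured compounds compound 2 holds the lowest number, compound 1 the highest, with compound 3 standing between them.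

Compound 4 is expected to move from compound 3 by about a 7.6-fold lower number from compound 3 to compound 4 (0.88 log units; beyond the scatter), a step of roughly the same size as the earlier 7.8-fold lower number from compound 1 to compound 2 (0.89 log units; beyond the scatter), which rests on the single measured occurrence of the identical change at the identical place. Compound 4 is therefore estimated at 2300 nM, with an expected range from 900 nM to 6000 nM.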

Compound 4, half-maximal inhibitory concentration: 2000 nM
Estimate against measurement, compound 4: 1.2-fold (0.06 log units) above; measured number inside the range.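

In this assay, phenyl in place of cyclohexyl gives an 8.8-fold lower number from compound 3 to compound 4 (0.94 log units; beyond the scatter), and the step keeps its size on the core that carries the methyl: the same change on two cores in this assay, a 7.8-fold lower number (0.89 log units; beyond the scatter) from compound 1 to compound 2 and an 8.8-fold lower number (0.94 log units; beyond the scatter) from compound 3 to compound 4, 1.1-fold (0.05 log units) apart, within the scatter of two such steps. Methyl in place of hydrogen, read on the phenyl-bearing pair, gives a 2.6-fold lower number from compound 2 to compound 4 (0.41 log units; beyond the scatter), and this step also repeats: the same change on two cores in this assay, a 2.3-fold lower number (0.37 log units; beyond the scatter) from compound 1 to compound 3 and a 2.6-fold lower number (0.41 log units; beyond the scatter) from compound 2 to compound 4, 1.1-fold (0.05 log units) apart, within the scatter of two such steps. The two changes therefore behave independently across these four compounds, but that rests on one carry-over of each change in a single assay, and it neither shows that they would do so on any other core nor explains why either change lowers the number.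

The compounds shown leave open what a longer chain in place of the benzyl would do, or an amine or a carboxylic acid on its phenyl ring. They also leave open whether a methoxy or a chlorine in place of the methyl would combine with the phenyl step in the same way.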